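Cytotoxicity notes on a small benzoxazolone acetamide series

The source may hold more compounds than are shown below. What is called first, only, known or untested is meant among the compounds shown, and "the series" means these compounds.

Measured so far:
compound 1 `O=C(Cn1c(=O)oc2ccccc21)Nc1nc2ccccc2s1`: 43.5%
compound 2 `O=C(Cn1c(=O)oc2ccccc21)Nc1cc(C(F)(F)F)ccc1Cl`: 12.3%
compound 3 `O=C(Cn1c(=O)oc2cc(Cl)ccc21)NCc1cccs1`: 20.3%

All three values come from an ADME assay on RAW264.7 cells (Mus musculus) for cytotoxicity, read by MTT assay, with a stated time of 72 h, tested at 50 uM; a higher number here means a stronger effect of the compound at the concentration tested, a lower number a weaker effect. Compound 3 stands second highest of the three numbers. Its nearest neighbour is compound 2, whose value of 12.3% lies within the scatter of that of compound 3, so no order between these two can be drawn. Compound 1, with 43.5%, sits beyond the scatter above compound 3. For the measured compounds named here, no pair of measured compounds differs in one place only, so no single step is known.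

The next compound, compound 4 `O=C(Cn1c(=O)oc2cc(Cl)ccc21)Nc1ccccc1`, differs from compound 3 by phenyl in place of (thiophen-2-yl)methyl on an amide-type nitrogen. The measured compounds give no direct guide to this change; compound 2, which also carries an aryl group on the amide-type nitrogen, shows a value close to that of compound 3. On this basis no step beyond the scatter is expected from compound 3 to compound 4 in this assay, with the estimated step being a number 2.3 percentage points lower from compound 3 to compound 4 (within the scatter). Compound 4 is expected to give about 18%, within a range of 5% to 35%.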

Compound 4, a percentage reported as inhibition, at one concentration (the size of the read-out at that concentration, not a potency): 15.8%
Estimate against measurement, compound 4: 2.2 percentage points above, within the range that was stated.
By their numbers in this assay, from the lowest: compounds 2, 4 and 3 (each within the scatter of the next); then compound 1.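

With the core of compound 3 held fixed, the series now has its first readable single change: phenyl in place of (thiophen-2-yl)methyl on an amide-type nitrogen gives a number 4.5 percentage points lower from compound 3 to compound 4 (within the scatter) in this assay and this step lies within the scatter. This position therefore accepts this exchange of one aromatic group for another, with its loss of the sulfur-bearing five-membered ring, without a change that can be resolved in this read-out. The step says nothing about other groups at this position, and a single pair supports no wider pattern.

Still open, from the compounds shown here alone, is whether an aliphatic amine, a carboxylic acid or a longer chain on this nitrogen would give a step beyond the scatter. No measurement at hand bears on the reason for this result.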